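A few compounds are considered here, and "the series" means these few. Any claim that something is new, unique, unknown or untested is made for them only; others in the source may bear on it.

Compound 1 `CC(C)=CC[C@@H]1C[C@]2(CC=C(C)C)C(=O)[C@@](CC=C(C)C)(C(=O)C(C(=O)c3ccc(O)c(O)c3)=C2O)C1(C)C` carries a (3,4-dihydroxyphenyl)carbonyl group on a prenylated core. In a functional assay on HCT-116 cells (Homo sapiens) for inhibition (on this read-out lower numbers stand for stronger inhibition and higher numbers for weaker inhibition), compound 1 gives 9.22 ug/mL, the higher of the two definite numbers shown. Compound 2 `CC(C)=CCC/C(C)=C/C[C@]12C[C@@H](CC=C(C)C)C(C)(C)[C@](CC=C(C)C)(C(=O)C(C(=O)c3ccc(O)c(O)c3)=C1O)C2=O` gives 8.6 ug/mL, indistinguishable from it, as a 1.1-fold lower number from compound 1 to compound 2 (0.03 log units; within the scatter) shows. Compound 3 `CC(C)=CCC/C(C)=C/C[C@@H]1C[C@]2(CC=C(C)C)C(=O)[C@@](CC=C(C)C)(C(=O)C(C(=O)c3ccc(O)c(O)c3)=C2O)C1(C)C` reaches only the limit of this assay, > 20 ug/mL. The step of an at least 2.1-fold higher number from compound 1 to compound 3 (0.33 log units; beyond the scatter) is thus a bound, resting on (the limit of > 20 ug/mL in this assay, at which 1 of the 3 values shown sits).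

Compound 4 `CC(C)=CC[C@@H]1C[C@]2(CC=C(C)C)C(=O)[C@@](CC=C(C)C)(C(=O)C(C(=O)c3ccccc3)=C2O)C1(C)C` differs from compound 1 by phenyl in place of 3,4-dihydroxyphenyl on a carbonyl carbon. Both measured steps move a 3-methylbut-2-en-1-yl group on a chain carbon and leave the aromatic ring untouched, so none of them bears on this change. Compound 4 is therefore expected near 15 ug/mL. The expected range for compound 4 runs from 7 ug/mL to 30 ug/mL. This expectation corresponds to a 1.6-fold higher number from compound 1 to compound 4 (0.21 log units; within the scatter).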

Compound 4, half-maximal inhibitory concentration: 6.87 ug/mL
For compound 4 the middle estimate is 2.2-fold (0.34 log units) above the measured one; the measured number lies below the stated range.
By their numbers in this assay, from the lowest: compounds 4, 2 and 1 (each within the scatter of the next). At a limit, above all of these: compound 3.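

The earlier steps shown here moved only a 3-methylbut-2-en-1-yl group, whereas here the aromatic ring itself changes: going from (3,4-dihydroxyphenyl)carbonyl to benzoyl gives a 1.3-fold lower number from compound 1 to compound 4 (0.13 log units; within the scatter) in this assay. On this carbonyl carbon, then, phenyl can stand in place of 3,4-dihydroxyphenyl, losing the ring's hydrogen-bond donors, and the read-out stays within the scatter. Nothing measured here gives a reason for this result. Still open, from the compounds shown here alone, is how an amine or a carboxylic acid on the phenyl ring would read in this assay. Also open, going by these compounds, is whether the same change holds on compound 2 and compound 3.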